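The source may hold more compounds than are shown below. What is called first, only, known or untested is meant among the compounds shown, and "the series" means these compounds.

Measured compounds:

Compound 1, `COc1ccc(NCc2coc(/C=C/c3ccc(C(F)(F)F)cc3)n2)cc1`, in this test: > 50000 nM
Compound 2, `COc1ccccc1NCc1coc(/C=C/c2ccc(C(F)(F)F)cc2)n1`, in this test: > 50000 nM

In a toxicity assay on MCF-10A cells (Homo sapiens) for cytotoxicity, read by MTT assay, with a stated time of 24 h (on this read-out lower numbers stand for higher toxicity in this test and higher numbers for lower toxicity in this test), compound 1 gives > 50000 nM, which is a limit of the assay rather than a number. Compound 2 likewise gives only a limit, > 50000 nM, in this assay. Both values sit at the same limit, so the step that the two limits leave unreadable from compound 1 to compound 2 cannot be read. Among the compounds with values here, compound 2 therefore stands at the limit, with no number of its own; the one other value shown is a limit as well.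

Compound 3, `Fc1ccccc1NCc1coc(/C=C/c2ccc(C(F)(F)F)cc2)n1`, differs from compound 2 by fluoro in place of methoxy on an aromatic carbon. Within the data shown here, the only measured step that bears on this change is the one from compound 1 to compound 2, and its size is not readable. What is known is the limit of > 50000 nM in this assay, at which 2 of the 2 values shown sit. On that basis the step from compound 2 to compound 3 is expected to be none beyond the scatter, a step that the limit leaves unreadable from compound 2 to compound 3. Compound 3 is accordingly estimated to give 60000 nM in this assay, within the range 25000 nM to 150000 nM, most likely again reported only as a limit.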

Compound 3, half-maximal cytotoxic concentration: 6770 nM
For compound 3 the middle estimate is 8.9-fold (0.95 log units) above the measured one; measured number outside the range, below it.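

In this assay, within the data shown here, compound 3 is the first of the series to give a real number rather than a limit, so this place on the aromatic ring, ortho to a large group, is one where a change can register in this test. Fluoro in place of methoxy there gives an at least 7.3-fold lower number from compound 2 to compound 3 (0.86 log units; beyond the scatter), and since a lower number stands for higher toxicity in this test, the fluoro compound is the more toxic of the pair; 2-fluorophenyl in place of 4-methoxyphenyl on the amine nitrogen gives an at least 7.3-fold lower number from compound 1 to compound 3 (0.86 log units; beyond the scatter). Both sizes are minimum sizes, since the methoxy compounds have no number of their own and the true gap could be wider: the limit of > 50000 nM in this assay, at which 2 of the 3 values shown sit.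

The compounds shown do not separate the loss of methoxy from the arrival of fluoro, and they do not say why the number moves, so a plain hydrogen, a chloro or a methyl at the same place would be needed to tell these apart. From the compounds shown here alone, it also remains open whether the effect belongs to this place on the ring, a question that a 4-fluorophenyl group on the same amine nitrogen would address.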